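Hydrazone series: acyl variation at the carbonyl carbon

This account rests on a few compounds, and the source may have more. Where it says the series, first, only, none or still open, it means among the compounds named here.

Of the compounds shown here, three built on a shared core have been measured in a functional assay on MCF7 cells (Homo sapiens) for cytotoxicity, read by sulforhodamine B assay, with a stated time of 48 h; a higher number here means a weaker inhibitor, a lower number a stronger inhibitor. Compound 1 `C/C(=N\NC(=O)CC#N)c1ccc(S(=O)(=O)N2CCCCC2)cc1` gives 44200 nM. Compound 2 `CCOC(=O)c1c(-c2ccc(O)c(OC)c2)c(C#N)c(=O)n(/N=C(\C)c2ccc(S(=O)(=O)N3CCCCC3)cc2)c1N` gives 38700 nM, and compound 3 `C/C(=N\n1c(N)cc(N)c(C#N)c1=O)c1ccc(S(=O)(=O)N2CCCCC2)cc1` gives 36400 nM. Compound 1 has the highest of the three numbers, yet its gaps to compound 2 and to compound 3 both lie within the usual scatter of repeated measurements, so on these data the three cannot be told apart; all sit at a weak level.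

Compound 4 `C/C(=N\NC(=O)c1sc(N)c(C#N)c1N)c1ccc(S(=O)(=O)N2CCCCC2)cc1` has not yet been measured. It differs from compound 1 in one place: 3,5-diamino-4-cyanothiophen-2-yl in place of cyanomethyl on a carbonyl carbon. Among the measured compounds shown here, no pair of measured compounds isolates a change of this kind, so the series itself gives no direction for it. What the series does show is that three quite different groups beyond the shared core all land at the same weak level, which argues for a small step rather than a large one. The expected step is a 1.4-fold lower number from compound 1 to compound 4 (0.14 log units; within the scatter), modest in size and most likely within the scatter. The estimate for compound 4 in this assay is 32000 nM, with a range from 12000 nM to 85000 nM.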

Compound 4, half-maximal inhibitory concentration: 49300 nM
Compound 4: the middle estimate sits 1.5-fold (0.19 log units) below what was measured, and the stated range covers the measured number.
By their numbers in this assay, from the lowest: compounds 3, 2, 1 and 4 (each within the scatter of the next).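

Notes on the carbonyl carbon whose other neighbour is an amide-type nitrogen: this pair gives the series its first single-place comparison, and in this assay the exchange of cyanomethyl for 3,5-diamino-4-cyanothiophen-2-yl is a 1.1-fold higher number from compound 1 to compound 4 (0.05 log units; within the scatter). At this place, therefore, a larger group carrying a five-membered aromatic ring and hydrogen-bond donors, which cyanomethyl lacks, gives a number that cannot be told apart from that of cyanomethyl, and the read-out stays at the same weak level. No supporting measurement bears on this flat outcome.

Among the compounds shown here, it remains open whether any group on this carbonyl carbon can move the number clearly away from the weak level, since a single pair within the scatter marks out only two groups at this place. A carboxylic acid or a longer chain such as n-butyl in place of cyanomethyl would probe this position further, and the same exchange on a second matched pair would show whether the flat result holds beyond compound 1 and compound 4.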